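Working notes: estimating compound 4 from compounds 1 to 3

The compounds below may be only part of what the source reports. "The series", "measured", "known", "first", "only" and "open" are said of these compounds alone.

Measured so far, in an assay on blood for inhibition of C-X-C chemokine receptor type 3 (Homo sapiens), with a stated time of 30 min; a higher number here means a weaker inhibitor, a lower number a stronger inhibitor:
- compound 1 `COc1ccc(-c2nc(C(F)(F)F)sc2N2CCN(C(=O)Cn3cnc4cccnc43)[C@H](C)C2)cc1`: 1190 nM
- compound 2 `COc1ncc(-c2nc(C(F)(F)F)sc2N2CCN(C(=O)Cn3cnc4cccnc43)[C@H](C)C2)cn1`: 158 nM
- compound 3 `CCCc1ncc(-c2nc(C(F)(F)F)sc2N2CCN(C(=O)Cn3cnc4cccnc43)[C@H](C)C2)cn1`: 45 nM

Compound 3 gives the lowest number of the three in this assay; its steps to both others are beyond the scatter, so it is the strongest inhibitor measured here. The step of a 7.5-fold lower number from compound 1 to compound 2 (0.88 log units; beyond the scatter) and the step of a 26-fold lower number from compound 1 to compound 3 (1.42 log units; beyond the scatter) show that the heteroaryl replacement carried most of the gain, while the step of a 3.5-fold lower number from compound 2 to compound 3 (0.55 log units; beyond the scatter) shows a further modest gain on going from the ether to the alkyl chain.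

Compound 4 `COCCOc1ncc(-c2nc(C(F)(F)F)sc2N2CCN(C(=O)Cn3cnc4cccnc43)[C@H](C)C2)cn1` is not yet measured. It differs from compound 3 by 2-methoxyethoxy in place of propyl on an aromatic carbon. The relevant comparison is the step from compound 2 to compound 3, which compound 4 partly reverses: an ether returns in this position, but with a longer chain than the methoxy of compound 2. A modest rise in the number is therefore expected, a 2.2-fold higher number from compound 3 to compound 4 (0.35 log units; beyond the scatter), landing compound 4 below compound 2 but above compound 3. For compound 4 the estimate in this assay is 100 nM, with a range from 30 nM to 350 nM.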

Compound 4, half-maximal inhibitory concentration: 182 nM
Beside the measured number, compound 4's estimate is 1.8-fold (0.26 log units) below it; the measured number falls inside the stated range.
By their numbers in this assay, from the lowest: compound 3; then compounds 2 and 4 (each within the scatter of the next); then compound 1.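

In this assay, replacing propyl with 2-methoxyethoxy on the pyrimidine carbon between the two ring nitrogen atoms gives a 4.0-fold higher number from compound 3 to compound 4 (0.61 log units; beyond the scatter), so both ether compounds shown, compound 2 and compound 4, give higher numbers than compound 3. Extending the ether chain leaves no readable difference, with a 1.2-fold higher number from compound 2 to compound 4 (0.06 log units; within the scatter) as the step. The advantage over the 4-methoxyphenyl group persists with the longer ether, as a 6.5-fold lower number from compound 1 to compound 4 (0.82 log units; beyond the scatter) shows for the 2-(2-methoxyethoxy)pyrimidin-5-yl group.

No supporting data explain these differences. As far as these compounds go, it remains open whether the higher numbers follow the ether oxygen attached to the ring or the chain as a whole, a question that a butyl chain, a 3-methoxypropyl chain or an amine attached at the same ring carbon would bear on.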